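The compounds below may be only part of what the source reports. "The series", "measured", "known", "first", "only" and "open" are said of these compounds alone.

Compound 1 `COc1ccc(-c2[nH]c3cc(OC)ccc3c2C=O)cc1`: 160 nM
Compound 2 `COc1ccc(-c2[nH]c3ccc(F)cc3c2C=O)cc1`: 240 nM

In a functional assay on MCF7 cells (Homo sapiens) for antiproliferative activity, with a stated time of 5 days (a lower number here means a stronger inhibitor, a higher number a weaker inhibitor), compound 2 gives 240 nM, which lies within the usual scatter of the result for compound 1, so the two cannot be told apart. Compound 3 `CCCCc1ccc2[nH]c(-c3ccc(OC)cc3)c(C=O)c2c1` has butyl in place of fluoro on an aromatic carbon. For the measured compounds named here, no measured pair shows a change at this place, so the expectation is uncertain: a modest move towards a lower number in this assay, perhaps slightly beyond the scatter. The expected step is a 3.0-fold lower number from compound 2 to compound 3 (0.48 log units; beyond the scatter). For compound 3 the estimated value is 80 nM, with an expected range from 12 nM to 500 nM.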

Compound 3, half-maximal inhibitory concentration: 22 nM
Beside the measured number, compound 3's estimate is 3.6-fold (0.56 log units) above it; low and high end bracket the measured number.
By their numbers in this assay, from the lowest: compound 3; then compounds 1 and 2 (each within the scatter of the next).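

In this assay, for the compounds shown here, putting butyl in place of fluoro on this aromatic carbon gives an 11-fold lower number from compound 2 to compound 3 (1.04 log units; beyond the scatter), the first step at this position and one well beyond the scatter. It shows that this place tolerates the larger butyl chain and that the exchange goes with a clear gain in potency. Nothing measured here accounts for the step. As far as these compounds go, a single pair cannot show whether the gain tracks chain length, so an ethyl or a hexyl chain remains open. Also open, from the compounds shown here alone, is how a butyl chain ending in an amine or a carboxylic acid would behave.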